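Nitrofuran amides on Vero cells: swapping the phenoxy group

A few compounds are considered here, and "the series" means these few. Any claim that something is new, unique, unknown or untested is made for them only; others in the source may bear on it.

Compound 1 `CC(C)(NC(=O)c1ccc([N+](=O)[O-])o1)c1ccccc1`, compound 2 `CC(C)(NC(=O)c1ccc([N+](=O)[O-])o1)c1ccc(-c2ccc(Cl)cc2)cc1` and compound 3 `CC(C)(NC(=O)c1ccc([N+](=O)[O-])o1)c1ccc(COc2ccc(Cl)cc2)cc1` share one core and differ only in the group on a single aromatic carbon. In an ADME assay on Vero cells (Chlorocebus sabaeus) for cytotoxicity, read by MTT assay, with a stated time of 48 h (a lower number here means that less compound is tolerated, a higher number that more compound is tolerated), compound 1 reaches only a limit, > 180000 nM, and not a number. Compound 2 likewise gives a limit in this assay, namely > 140000 nM. Within the data shown here, compound 3 is the one compound with a measured number in this assay, where compound 3 gives 120000 nM. The step of an at least 1.5-fold lower number from compound 1 to compound 3 (0.17 log units; that floor lies within the scatter) and the step of an at least 1.1-fold lower number from compound 2 to compound 3 (0.06 log units; that floor lies within the scatter) are thus known only as floors, and both floors lie within the scatter; the step that the two limits leave unreadable from compound 1 to compound 2 stays unreadable, as the limit of > 140000 nM in this assay, at which 1 of the 3 values shown sits, and the limit of > 180000 nM in this assay, at which 1 of the 3 values shown sits, show.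

Compound 4 `CC(C)(NC(=O)c1ccc([N+](=O)[O-])o1)c1ccc(COc2ccccc2OC(F)(F)F)cc1` differs from compound 3 by 2-(trifluoromethoxy)phenyl in place of 4-chlorophenyl on an oxygen on a saturated carbon. Among the measured compounds shown here, no measured step touches this oxygen; all three concern the aromatic carbon and show nothing beyond the scatter. The account therefore expects the step of a 1.1-fold lower number from compound 3 to compound 4 (0.04 log units; within the scatter) to be none beyond the scatter. Compound 4 is expected to give 110000 nM in this assay. For compound 4 the expected range runs from 55000 nM to 220000 nM, with a fair chance that only a limit is reported.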

Compound 4, half-maximal cytotoxic concentration: 13000 nM
Estimate against measurement, compound 4: 8.5-fold (0.93 log units) above; measured number below the stated range.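

In this assay, among these compounds, placing 2-(trifluoromethoxy)phenyl instead of 4-chlorophenyl on the oxygen on a saturated carbon gives a 9.2-fold lower number from compound 3 to compound 4 (0.97 log units; beyond the scatter), the first step that is readable beyond the scatter. The earlier steps shown here all concerned the aromatic carbon and gave only floors within the scatter, whereas this one shows that the group on this oxygen can change how much compound the Vero cells tolerate. Nothing among the measurements shown accounts for the size of this step, which therefore stands as an observation without an explanation.

Because the step swaps the substituent and its ring position together, this single pair cannot show whether the change follows from losing the 4-chlorophenyl, from gaining the trifluoromethoxy group or from where that group sits on the ring. The compounds shown leave open what plain phenyl, 2-chlorophenyl or 4-(trifluoromethoxy)phenyl on the same oxygen would give, and whether an amine or a carboxylic acid on that ring would move the number in the same direction.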